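The source may report more compounds than this note shows. Statements on the series, on what has been measured and on what is new or still open speak of the compounds shown alone.

Among the measured compounds shown here, compound 1 `O=C(NNc1nncc2ccccc12)C1CC1c1ccc(OCC(F)(F)F)cc1` is the only member of the series with a number in a functional assay on PC-3 cells (Homo sapiens) for inhibition, read by MTT assay, with a stated time of 72 h; a lower number here means a stronger inhibitor, a higher number a weaker inhibitor: compound 1 gives 67000 nM. Compound 2 `CC(C)=CCOc1ccc(C2CC2C(=O)NNC(=O)c2ccncc2)cc1` reaches only a limit in this assay, giving > 100000 nM. Compound 3 `COc1ccc(C2CC2C(=O)NNC(=O)c2ccncc2)cc1` likewise stops at a limit, giving > 100000 nM. For the measured compounds named here, the single change between measured compounds, a step that the two limits leave unreadable from compound 2 to compound 3, therefore cannot be sized, a direct consequence of the limit of > 100000 nM in this assay, at which 2 of the 3 values shown sit. Compound 4 `CC(C)=CCC/C(C)=C/COc1ccc(C2CC2C(=O)NNc2nncc3ccccc23)cc1` differs from compound 1 by 2,6-dimethylhepta-1,5-dien-1-yl in place of trifluoromethyl on a saturated chain carbon bound to an oxygen on an aromatic ring. Going by the values given here, the variation of the chain on the oxygen between compound 2 and compound 3 is the nearest kind of change, and it is unreadable, so no measured step gives either the size or the direction of the step to compound 4. The working expectation is a step no larger than the scatter, a 1.0-fold higher number from compound 1 to compound 4 (0.02 log units; within the scatter). Compound 4 is accordingly estimated at 70000 nM, within 25000 nM to 200000 nM, with a fair chance that this assay returns only a limit for it.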

Compound 4, half-maximal inhibitory concentration: 24000 nM
Beside the measured number, compound 4's estimate is 2.9-fold (0.46 log units) above it, outside the stated range (below it).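

On the saturated chain carbon bound to an oxygen on an aromatic ring, this assay now gives its first readable step, a 2.8-fold lower number from compound 1 to compound 4 (0.45 log units; beyond the scatter). This position therefore takes 2,6-dimethylhepta-1,5-dien-1-yl, with 9 heavy atoms entering for the 4 of trifluoromethyl, and the number falls rather than rises. The earlier change of the chain on this oxygen gave neither size nor direction, because both of its ends are limits: the limit of > 100000 nM in this assay, at which 2 of the 4 values shown sit.

This rests on a single pair of compounds, so it shows no trend with chain size and does not separate the effect of chain length from that of the 2 double bonds. A saturated octyl chain on the same oxygen of the core of compound 1 would separate the two, and an amine at the chain end would test whether this position also takes a non-hydrocarbon end group.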